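This account rests on a few compounds, and the source may have more. Where it says the series, first, only, none or still open, it means among the compounds named here.

In a functional assay on HEK293 cells (Homo sapiens), read by cAMP accumulation (a higher number here means that more compound is needed for the effect, a lower number that less compound is needed), the measured compounds are:
- compound 1 `CCCC1=C(C(=O)OCC)C(c2cccc(C)c2)NC(=O)N1` with 7500 nM 
- compound 2 `CCCC1=C(C(=O)OCC)C(c2cc(C)cc(C)c2)NC(=O)N1` with 9500 nM 

Within the data shown here, compound 1 cannot be ranked apart from the only other measured compound. Among the measured compounds shown here, the single measured step, a 1.3-fold higher number from compound 1 to compound 2 (0.10 log units; within the scatter), is a methyl in place of hydrogen on an aromatic carbon, and it stays within the usual scatter.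

Compound 3 `CCCC1=C(C(=O)OCc2ccc(C(=O)O)cc2)C(c2cccc(C)c2)NC(=O)N1` keeps the core of compound 1 but changes a different part of the molecule. The change is 4-carboxyphenyl in place of methyl on a saturated chain carbon bound to an oxygen next to a carbonyl group, so that 4-carboxyphenyl stands in place of methyl on a saturated chain carbon bound to an oxygen next to a carbonyl group. Cut one bond further out, this reads ethyl to 4-carboxybenzyl.

The measured step concerns a much smaller change elsewhere, so it gives little guidance here. No measurement shows the size or direction of this new change. A step beyond the scatter seems possible for so large a change, and a lower number is only a tentative expectation. The estimated step is a 3.0-fold lower number from compound 1 to compound 3 (0.48 log units; beyond the scatter) in this assay, with great uncertainty. For compound 3 the expected value is 2500 nM, within an estimated range of 150 nM to 15000 nM overall.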

Compound 3, half-maximal effective concentration: 3400 nM
Estimate against measurement, compound 3: 1.4-fold (0.13 log units) below, within the range that was stated.
By their numbers in this assay, from the lowest: compound 3; then compounds 1 and 2 (each within the scatter of the next).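

In this assay, the place that had not yet been explored turns out to respond to change (a 2.2-fold lower number from compound 1 to compound 3 (0.34 log units; beyond the scatter)), a modest step, but one that lies beyond the scatter, unlike the earlier step on the aromatic ring. Going from ethyl to 4-carboxybenzyl brings in a six-membered aromatic ring of carbon only, together with a hydrogen-bond donor and a hydrogen-bond acceptor, yet less compound, not more, is needed for the effect, so this place accepts a much larger group with no loss in this read-out. Nothing available explains why the number fell.

The compounds shown leave open whether the lower number belongs to the added ring or to the carboxylic acid it carries, a question that a plain benzyl group at the same place would separate. They also leave open how far this place can be pushed, for example with a longer chain or an amine, and whether the same change would give a similar step on the core of compound 2.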